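A few compounds are considered here, and "the series" means these few. Any claim that something is new, unique, unknown or untested is made for them only; others in the source may bear on it.

Measured so far in a functional assay on SF-295 cells (Homo sapiens) for cytotoxicity; on this read-out higher numbers stand for weaker inhibition of growth and lower numbers for stronger inhibition of growth:
compound 1, `OCCCCC#Cc1ccccc1C#Cc1ccccc1`: 150 nM
compound 2, `OCCCCC#Cc1ccccc1C#Cc1ccc(O)cc1`: 16200 nM
compound 3, `OCCCCC#Cc1ccccc1C#Cc1ccc(C(F)(F)F)cc1`: 19100 nM

Compound 3 sits at the upper end of the numbers in this assay, alongside compound 2; the gap a 1.2-fold higher number from compound 2 to compound 3 (0.07 log units; within the scatter) carries no weight, whereas the gap a 130-fold higher number from compound 1 to compound 3 (2.10 log units; beyond the scatter) is large and clear.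

Compound 4, `N#Cc1ccc(C#Cc2ccccc2C#CCCCCO)cc1`, differs from compound 3 in one place: cyano in place of trifluoromethyl on an aromatic carbon.

Among the compounds with values here, two measured steps bear on this. The step of a 110-fold higher number from compound 1 to compound 2 (2.03 log units; beyond the scatter) and the step of a 130-fold higher number from compound 1 to compound 3 (2.10 log units; beyond the scatter) both show that placing a group on that aromatic carbon, whether hydroxy or trifluoromethyl, moves the number far upward relative to compound 1. The step of a 1.2-fold higher number from compound 2 to compound 3 (0.07 log units; within the scatter) then shows that the two groups tried there give indistinguishable numbers. Cyano is a third group at the same place; with no evidence that the nature of the group matters, the expectation for compound 4 is a number close to compound 3, with a step of a 1.3-fold lower number from compound 3 to compound 4 (0.10 log units; within the scatter) that stays within the scatter. Compound 4 is therefore estimated at 15000 nM, ranging from 4000 nM to 50000 nM.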

Compound 4, concentration for 50% growth inhibition: 21500 nM
Compound 4: middle estimate off by 1.4-fold (0.16 log units), on the low side; the range from low to high includes it.
By their numbers in this assay, from the lowest: compound 1; then compounds 2, 3 and 4 (each within the scatter of the next).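

In this assay, cyano on this aromatic carbon, para to a large group, falls with the two groups already tried there: a 1.1-fold higher number from compound 3 to compound 4 (0.05 log units; within the scatter) against trifluoromethyl and a 1.3-fold higher number from compound 2 to compound 4 (0.12 log units; within the scatter) against hydroxy. Three groups now share this level, including one with a triple bond and a hydrogen-bond acceptor, so no difference among them can be read. Against hydrogen the change stays large, at a 140-fold higher number from compound 1 to compound 4 (2.16 log units; beyond the scatter), which leaves compound 1 alone among the four, and nothing on hand accounts for that gap.

As far as these compounds go, whether fluorine or methyl on this carbon stays with compounds 2, 3 and 4 or comes closer to compound 1 remains open. So does whether an amine or a carboxylic acid there would give the same level.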